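The source may report more compounds than this note shows. Statements on the series, on what has been measured and on what is new or still open speak of the compounds shown alone.

Measured so far in a functional assay on SMMC-7721 cells (Homo sapiens) for inhibition, read by CCK-8 assay, with a stated time of 72 h, tested at 2 uM; a lower number here means less inhibition of growth, a higher number more inhibition of growth at the concentration tested:
- compound 1 (`Cc1cc(C)cc(SCc2ccc(/C=C/C(=O)Nc3ccccc3N)cc2)c1`) gives 8.61%
- compound 2 (`Nc1ccccc1NC(=O)/C=C/c1ccc(CSc2ccc(Cl)cc2)cc1`) gives 15.2%
- compound 3 (`Nc1ccccc1NC(=O)/C=C/c1ccc(CSc2cccc(F)c2)cc1`) gives 8.56%

Compound 3 stands level with the other two, with steps to it of (a number 0.1 percentage points lower from compound 1 to compound 3 (within the scatter)) and (a number 6.6 percentage points lower from compound 2 to compound 3 (within the scatter)), so no order among the three can be read.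

The next change leads to compound 4 (`CCc1ccc(SCc2ccc(/C=C/C(=O)Nc3ccccc3N)cc2)cc1`), with 4-ethylphenyl in place of 3-fluorophenyl on a sulfur. All three measured steps bear on it, since each swaps the group on that same sulfur. The step to compound 2 (a number 6.6 percentage points higher from compound 1 to compound 2 (within the scatter)) is as large as any of them. Among the measured compounds shown here, none of the measured compounds carries 4-ethylphenyl, so the expectation rests only on these small steps. No step beyond the scatter is therefore expected in this assay.

The expected step is small (a number 1.4 percentage points higher from compound 3 to compound 4 (within the scatter)). Compound 4 is estimated at 10%, with an expected range from 2% to 22%.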

Compound 4, percent growth inhibition at one concentration: 13.2%
Beside the measured number, compound 4's estimate is 3.2 percentage points below it, and the stated range covers the measured number.
By their numbers in this assay, from the lowest: compounds 3, 1, 4 and 2 (each within the scatter of the next).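

In this assay, 4-ethylphenyl on the sulfur extends the set of aryl groups tested at this position, and the steps to it from the two groups it replaces are a number 4.6 percentage points higher from compound 3 to compound 4 (within the scatter) and a number 4.6 percentage points higher from compound 1 to compound 4 (within the scatter). Ethyl in place of chloro on an aromatic carbon is the first step in the series limited to a single group on that ring, and it reads a number 2 percentage points lower from compound 2 to compound 4 (within the scatter), so an alkyl group and a halogen are not told apart here. No accompanying data explain any of these steps.

The four compounds shown carry only alkyl groups or a halogen on this ring, so it remains open whether an amine, a carboxylic acid or a longer chain would give a step beyond the scatter. No order among the four can be read.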